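Moving the amino group from compound 2 to compound 4

This account rests on a few compounds, and the source may have more. Where it says the series, first, only, none or still open, it means among the compounds named here.

In a functional assay on COR-L23 cells (Homo sapiens) for antiproliferative activity, read by CellTiter-Glo, with a stated time of 72 h (a higher number here means a weaker inhibitor, a lower number a stronger inhibitor), compound 1 `C[C@@H](c1ccc(NC(=O)N2CC(c3cccnc3)C2)cc1)N1Cc2ccccc2C1=O` gives 8 nM while compound 2 `C[C@@H](c1ccc(NC(=O)N2CC(c3ccc(N)nc3)C2)cc1)N1Cc2ccccc2C1=O` gives 19 nM and compound 3 `C[C@H](NC(=O)c1ncccn1)c1ccc(NC(=O)N2CC(c3ccc(N)nc3)C2)cc1` gives 160 nM as its reading. Compound 2 thus holds the middle place among these three numbers.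

Compound 4 `C[C@@H](c1ccc(NC(=O)N2CC(c3cncc(N)c3)C2)cc1)N1Cc2ccccc2C1=O` has the same atoms as compound 2, joined differently, with 5-aminopyridin-3-yl in place of 6-aminopyridin-3-yl on a saturated ring carbon.

The nearest evidence is amino in place of hydrogen on an aromatic carbon, which gave a 2.4-fold higher number from compound 1 to compound 2 (0.38 log units; beyond the scatter) and counts as a modest change. The other measured change (an 8.4-fold higher number from compound 2 to compound 3 (0.93 log units; beyond the scatter)) is also modest, but it replaced a different group and says little about this one. For the measured compounds named here, no measured compound has the amino group at the new place, so the data give no direction, and only a small change is expected (a 1.1-fold higher number from compound 2 to compound 4 (0.02 log units; within the scatter)). The estimate for compound 4 is 20 nM with 7 nM to 60 nM as its expected range.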

Compound 4, half-maximal inhibitory concentration: 130 nM
Beside the measured number, compound 4's estimate is 6.5-fold (0.81 log units) below it, outside the stated range (above it).
By their numbers in this assay, from the lowest: compound 1; then compound 2; then compounds 4 and 3 (each within the scatter of the next).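

In this assay, the place of the amino group on the aromatic ring matters: 5-aminopyridin-3-yl in place of 6-aminopyridin-3-yl gives a 6.8-fold higher number from compound 2 to compound 4 (0.84 log units; beyond the scatter), although the two groups have the same atoms and the same counts of hydrogen-bond donors and acceptors. Adding an amino group to the unsubstituted ring of compound 1 therefore has a cost that depends on where it goes: a 16-fold higher number from compound 1 to compound 4 (1.21 log units; beyond the scatter), a larger loss than a 2.4-fold higher number from compound 1 to compound 2 (0.38 log units; beyond the scatter). No measurement here explains why the new place is so much less well tolerated.

The compounds shown leave open whether this loss is specific to the amino group, or whether a 5-hydroxypyridin-3-yl or 5-methylpyridin-3-yl group would weaken activity as well. They also leave open whether the same move would cost as much with the side group carried by compound 3.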